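The source may report more compounds than this note shows. Statements on the series, on what has been measured and on what is new or still open speak of the compounds shown alone.

Measured in a functional assay on HT-29 cells (Homo sapiens) for antiproliferative activity, read by MTT assay, with a stated time of 24 h; on this read-out higher numbers stand for weaker inhibition and lower numbers for stronger inhibition:
- Compound 1 `COc1ccc(C(=O)/C=C/c2ccc(F)cc2)c2c1C=CC(C)(C)O2`: > 10000 nM
- Compound 2 `COc1ccccc1/C=C/C(=O)c1ccc(OC)c2c1OC(C)(C)C=C2`: > 10000 nM

Both entries are limits of the assay, not numbers. Compound 2 stands at > 10000 nM, which is a limit. Compound 1 gives > 10000 nM, which is also a limit. The whole picture so far is therefore (the limit of > 10000 nM in this assay, at which 2 of the 2 values shown sit).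

Compound 3 `COc1ccc(C(=O)/C=C/c2cccc(O)c2)c2c1C=CC(C)(C)O2` keeps the shared core and differs from compound 2 in one place: 3-hydroxyphenyl in place of 2-methoxyphenyl on a double-bonded chain carbon bound to a double-bonded chain carbon. Here, 3-hydroxyphenyl takes the place of 2-methoxyphenyl on a double-bonded chain carbon bound to a double-bonded chain carbon.

Among the measured compounds shown here, the only measured step is a step that the two limits leave unreadable from compound 1 to compound 2, so it offers no size or direction to carry over. In this assay, no step beyond the scatter is expected, and a further limit is the likeliest report. The estimated step is a step that the limit leaves unreadable from compound 2 to compound 3. The expected value for compound 3 is 12000 nM, with an estimated range from 4000 nM to 30000 nM.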

Compound 3, half-maximal inhibitory concentration: > 10000 nM
Compound 3 gave a limit, no number; the forecaster's own chance of this, stated with the estimate: 65%; the middle value does not contradict the limit.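

No step among compound 1, compound 2 and compound 3 can be read, in size or in direction, since each result is a limit and not a number: the limit of > 10000 nM in this assay, at which 3 of the 3 values shown sit.

The compounds shown leave open whether 4-fluorophenyl, 2-methoxyphenyl and 3-hydroxyphenyl differ at all in this assay.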